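The source may report more compounds than this note shows. Statements on the series, on what has been measured and on what is new or still open speak of the compounds shown alone.

Measured in an ADME assay on Huh-7 cells (Homo sapiens) for cytotoxicity, read by thymidine incorporation; a lower number here means that less compound is tolerated, a higher number that more compound is tolerated:
- Compound 1 `CCc1cn([C@H]2C[C@H](N=[N+]=[N-])[C@@H](CO)O2)c(=O)[nH]c1=O`: > 100 ug/mL, a limit
- Compound 2 `[N-]=[N+]=N[C@H]1C[C@H](n2cc(Cl)c(=O)[nH]c2=O)O[C@@H]1CO`: > 100 ug/mL, a limit
- Compound 3 `[N-]=[N+]=N[C@H]1C[C@H](n2cc(Br)c(=O)[nH]c2=O)O[C@@H]1CO`: > 100 ug/mL, a limit

Compound 1 has no number in this assay, only the limit > 100 ug/mL. The three measured compounds share (the limit of > 100 ug/mL in this assay, at which 3 of the 3 values shown sit).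

Compound 4 `CCc1cn([C@H]2C[C@H](I)[C@@H](CO)O2)c(=O)[nH]c1=O` has iodo in place of azido on a saturated ring carbon.

The measured steps are a step that the two limits leave unreadable from compound 1 to compound 2, a step that the two limits leave unreadable from compound 1 to compound 3 and a step that the two limits leave unreadable from compound 2 to compound 3. Each of them exchanges a group on an aromatic carbon and leaves the azido in place, so they give no size for this change. Among the measured compounds shown here, no measured step touches the saturated ring carbon, so no step beyond the scatter can be predicted from the data. Compound 1 sits at the limit > 100 ug/mL, so only a move to a lower number could be read.

The expected outcome is a number no higher from compound 1 to compound 4 (the limit leaves the size open), with no clear change foreseen. For compound 4 the estimate is 100 ug/mL, within an expected range of 30 ug/mL to 200 ug/mL.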

Compound 4, half-maximal cytotoxic concentration: > 100 ug/mL
Compound 4 ended at the assay's limit (the forecaster's own chance of this, stated with the estimate: 70%); the middle value sits exactly at the limit.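

No step from compound 1 to compound 4 can be read in this assay, and both values are limits: the limit of > 100 ug/mL in this assay, at which 4 of the 4 values shown sit.

The compounds shown leave open how much of any of the four is tolerated, and whether iodo in place of azido changes that at all.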